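This account rests on a few compounds, and the source may have more. Where it says the series, first, only, none or still open, it means among the compounds named here.

Measured so far in a physicochemical assay for solubility, at pH 7.4; a lower number here means a less soluble compound, a higher number a more soluble compound:
compound 1 `NS(=O)(=O)c1ccc(SCCCO)c(Cl)c1`: 280 ug/mL
compound 2 `NS(=O)(=O)c1ccc(SCCCO)c(F)c1`: 900 ug/mL
compound 3 `COC(=O)c1cc(S(N)(=O)=O)ccc1S(=O)(=O)CCO`: 33400 ug/mL

Compound 3 stands highest of the three, and the values of the other two lie beyond the scatter from it. Compound 4 `COC(=O)c1cc(S(N)(=O)=O)ccc1SCCCO` has not yet been measured. Its difference from compound 3 is (3-hydroxypropyl)sulfanyl in place of (2-hydroxyethyl)sulfonyl on an aromatic carbon, at a position ortho to a methoxycarbonyl group and para to a sulfamoyl group.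

Among the measured compounds shown here, no measured step covers this exchange. For the measured compounds named here, the only step available, a 3.2-fold higher number from compound 1 to compound 2 (0.51 log units; beyond the scatter), is fluoro in place of chloro with the (3-hydroxypropyl)sulfanyl group kept, and it is modest. Its bearing is indirect: both of its compounds already carry the entering group, but neither has the methoxycarbonyl group that compound 4 retains. With that caveat, compound 1 at 280 ug/mL and compound 2 at 900 ug/mL are the best available guide to where compound 4 may fall. A large step to a lower number in this assay is therefore expected, well beyond the scatter. The expected step is a 67-fold lower number from compound 3 to compound 4 (1.82 log units; beyond the scatter). Compound 4 is estimated at 500 ug/mL, with an expected range from 150 ug/mL to 1800 ug/mL.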

Compound 4, solubility: 1300 ug/mL
Compound 4: the middle estimate sits 2.6-fold (0.41 log units) below what was measured, within the range that was stated.
By their numbers in this assay, from the lowest: compound 1; then compounds 2 and 4 (each within the scatter of the next); then compound 3.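

In this assay, among the compounds shown here, (3-hydroxypropyl)sulfanyl in place of (2-hydroxyethyl)sulfonyl, on the aromatic carbon ortho to a methoxycarbonyl group and para to a sulfamoyl group, gives a 26-fold lower number from compound 3 to compound 4 (1.41 log units; beyond the scatter), the first measured change at this position. With (3-hydroxypropyl)sulfanyl kept, methoxycarbonyl in place of fluoro gives a 1.4-fold higher number from compound 2 to compound 4 (0.16 log units; within the scatter), and methoxycarbonyl in place of chloro gives a 4.6-fold higher number from compound 1 to compound 4 (0.67 log units; beyond the scatter). Among these compounds, the exchange at this position therefore gives a much larger step than either exchange of fluoro or chloro for methoxycarbonyl, and compound 4 stays within the scatter of compound 2.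

On these data alone, the step from compound 3 changes sulfonyl to sulfanyl and the chain together, so the share of each stays open; a (2-hydroxyethyl)sulfanyl or (3-hydroxypropyl)sulfonyl group would separate them, and a carboxylic acid in place of methoxycarbonyl would test that other site further. No supporting data at hand bear on why these steps have the sizes they do.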